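Removing the Fluoro Substituent: Does It Change the Dose?

A few compounds are considered here, and "the series" means these few. Any claim that something is new, unique, unknown or untested is made for them only; others in the source may bear on it.

Of the compounds shown here, two sharing one core have been tested in a functional assay on the whole organism (strain NMRI) with Mus musculus as the target, with a stated time of 0.5 h; a higher number here means that more compound is needed for the effect, a lower number that less compound is needed. Compound 1 `O=[N+]([O-])c1ccc(Cn2cc(CO/N=C/c3c(-c4ccc(F)cc4)nc4ccc(Br)cn34)nn2)cc1` gives in this assay 40 mg/kg. Compound 2 `COc1ccc(Cn2cc(CO/N=C/c3c(-c4ccc(C)cc4)nc4c(C)cccn34)nn2)cc1` differs from compound 1 in several places at once, and in this assay compound 2 gives 40 mg/kg. The two values are level at the digits shown and lie within the scatter of repeated measurements, so no ordering between them can be claimed.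

Compound 3 `O=[N+]([O-])c1ccc(Cn2cc(CO/N=C/c3c(-c4ccccc4)nc4ccc(Br)cn34)nn2)cc1` is compound 1 altered in one place only: hydrogen in place of fluoro on an aromatic carbon. Within the data shown here, no measured pair differing in a single place is available, so there is no step to lean on. Because compound 1 gives 40 mg/kg while compound 2, with several differences, gives 40 mg/kg, the dose appears insensitive to such changes here. The step of no change at the digits printed from compound 1 to compound 3 (within the scatter) is therefore expected to be none beyond the scatter. Compound 3 is estimated at 40 mg/kg, within 20 mg/kg to 80 mg/kg.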

Compound 3, minimum effective dose: 20 mg/kg
Compound 3: middle estimate off by 2.0-fold (0.30 log units), on the high side; low and high end bracket the measured number.
By their numbers in this assay, from the lowest: compounds 3, 1 and 2 (each within the scatter of the next).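

Among these compounds, compound 1 and compound 3 form the first pair here that differs in one place only, so the fluoro group can be judged on its own. In this assay the change from 4-fluorophenyl to phenyl gives a 2.0-fold lower number from compound 1 to compound 3 (0.30 log units; within the scatter) and so shows that, in this pair, the dose needed does not depend measurably on the fluoro group at this position. No measurement at hand offers an explanation for this step.

Still open, on these data alone, is how the dose responds when an amine or a carboxylic acid sits on this aromatic carbon in place of hydrogen or fluoro. A single pair also cannot tell whether hydrogen in place of fluoro would read the same way with the other groups found in compound 2.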